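Methoxy in place of methyl: notes on the series

This account rests on a few compounds, and the source may have more. Where it says the series, first, only, none or still open, it means among the compounds named here.

Among the measured compounds shown here, in a functional assay on MV4-11 cells (Homo sapiens) for antiproliferative activity (a higher number here means a weaker inhibitor, a lower number a stronger inhibitor), compound 1 (`NC(=O)c1c(NC(=O)c2ccco2)sc2c1CCCC2`) gives 1500 nM and compound 2 (`Cc1ccc(C(=O)Nc2sc3c(c2C(N)=O)CCCC3)cc1`) gives 450 nM as the lower of the two numbers so far. For the measured compounds named here, the only measured step is a 3.3-fold lower number from compound 1 to compound 2 (0.52 log units; beyond the scatter) for 4-methylphenyl in place of furan-2-yl on a carbonyl carbon, modest but beyond the scatter. Compound 3 (`COc1ccc(C(=O)Nc2sc3c(c2C(N)=O)CCCC3)cc1`) has methoxy in place of methyl on an aromatic carbon, para to a large group (methoxy in place of methyl on an aromatic carbon). The measured step exchanges a different group and bears only loosely on this smaller change. Going by the values given here, no measured step covers methoxy or this place, so the data give no direction, and no step beyond the scatter is expected in this assay from this change. The estimate for compound 3 is 420 nM with an expected range of 170 nM to 1000 nM in this series. The estimated step is a 1.1-fold lower number from compound 2 to compound 3 (0.03 log units; within the scatter) and thus small.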

Compound 3, half-maximal inhibitory concentration: 1300 nM
For compound 3 the middle estimate is 3.1-fold (0.49 log units) below the measured one, and the stated range ends below it.
By their numbers in this assay, from the lowest: compound 2; then compounds 3 and 1 (each within the scatter of the next).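

In this assay, methoxy in place of methyl on an aromatic carbon, para to a large group, gives a 2.9-fold higher number from compound 2 to compound 3 (0.46 log units; beyond the scatter), a modest step showing that this position responds to an exchange this small, which the earlier step on the carbonyl carbon could not show. The advantage of compound 2 does not carry over to the methoxy analogue, since compound 3 at 1300 nM and compound 1 at 1500 nM lie within the scatter of each other. No measurement at hand accounts for this step.

As far as these compounds go, whether a chlorine, an amine or a longer chain such as ethyl at this place would stay with compound 2 or fall with compound 3 remains open. Also open, from the compounds shown here alone, is whether methoxy in place of methyl gives a similar step elsewhere on the aromatic ring.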